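Swapping Carbamoyl for Aminomethyl on a Poorly Soluble Compound

The source may report more compounds than this note shows. Statements on the series, on what has been measured and on what is new or still open speak of the compounds shown alone.

In a physicochemical assay for solubility (on this read-out higher numbers stand for higher solubility and lower numbers for lower solubility), compound 2 (`NC(=O)c1ccccc1NC(=O)c1cc2cc([N+](=O)[O-])ccc2o1`) gives 5 ug/mL and stands level with compound 3 (`NC(=O)c1ccccc1NC(=O)c1cnc2ccccc2c1`) at 5 ug/mL within the scatter of repeat measurements. Compound 1 (`COC(=O)c1ccc(NC(=O)c2ccc3ccccc3c2)cc1`) reaches 25 ug/mL and sits clearly higher than both. Compound 4 (`NCc1ccccc1NC(=O)c1cc2cc([N+](=O)[O-])ccc2o1`) is still unmeasured and carries aminomethyl in place of carbamoyl on an aromatic carbon while the rest of compound 2 stays the same. Within the data shown here, no measured pair isolates a single change, so the size of this step rests on judgement alone. A modest rise beyond the scatter in this assay is expected. The estimated change (a 3.0-fold higher number from compound 2 to compound 4 (0.48 log units; beyond the scatter)) is upward but uncertain. For compound 4 the estimated value is 15 ug/mL with a likely range from 5 ug/mL to 60 ug/mL on this read-out.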

Compound 4, solubility: 5 ug/mL
Estimate against measurement, compound 4: 3.0-fold (0.48 log units) above, within the range that was stated.
By their numbers in this assay, from the lowest: compounds 2, 3 and 4 (each within the scatter of the next); then compound 1.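

In this assay, among these compounds, aminomethyl in place of carbamoyl on an aromatic carbon, ortho to a large group, gives no change at the digits printed from compound 2 to compound 4 (within the scatter) and so provides the only comparison here that isolates a single change. At this position, on this core, exchanging one of these groups for the other leaves the read-out level. No available measurement gives a reason for this result.

As far as these compounds go, whether a carboxylic acid or a longer chain such as aminoethyl would read differently at this position remains open. So does whether the same exchange would leave the read-out level on the core of compound 3.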